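Moving the halogen on the aryl ring of the thioether side chain

The source may hold more compounds than are shown below. What is called first, only, known or untested is meant among the compounds shown, and "the series" means these compounds.

Compound 3 `C#CCNC1CCc2c(SCCc3ccc(Cl)cc3)cccc21` carries a 4-chlorophenyl on the chain beyond the sulfur and, in an ADME assay on isolated protein for inhibition of Amine oxidase [flavin-containing] B (Homo sapiens) (a higher number here means a weaker inhibitor, a lower number a stronger inhibitor), compound 3 gives 920 nM. Of the two numbers available, this is the lowest; the nearest neighbour is compound 2 `C#CCNC1CCc2c(SCCc3ccc(OC)cc3)cccc21`, which in this assay gives 4590 nM, so that a 5.0-fold lower number from compound 2 to compound 3 (0.70 log units; beyond the scatter). Compound 1 `C#CCNC1CCc2c(SCCc3ccc(F)c(F)c3)cccc21` belongs to the same series, but in this assay compound 1 gives "not determined" (no result reported).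

Compound 4 `C#CCNC1CCc2c(SCCc3cccc(F)c3)cccc21` differs from compound 3 in one place: 3-fluorophenyl in place of 4-chlorophenyl on a saturated chain carbon, two bonds along the chain from a sulfur. Among the compounds with values here, no measured pair in this set changes the aryl ring in just this way; the single step from compound 2 to compound 3 swaps one group for another while keeping its place, and cannot be carried over directly. Within the data shown here, with only that step to go on, the expectation for compound 4 is a number close to that of compound 3 or somewhat higher, so that the expected step is a 1.6-fold higher number from compound 3 to compound 4 (0.21 log units; within the scatter). For compound 4 the estimate in this assay is 1500 nM, within a range from 500 nM to 5000 nM.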

Compound 4, half-maximal inhibitory concentration: 7810 nM
Compound 4: the middle estimate sits 5.2-fold (0.72 log units) below what was measured; the whole stated range lies below it.
By their numbers in this assay, from the lowest: compound 3; then compounds 2 and 4 (each within the scatter of the next).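

In this assay, the aryl ring on a saturated chain carbon, two bonds along the chain from a sulfur, proves sensitive to this change: 3-fluorophenyl in place of 4-chlorophenyl gives (an 8.5-fold higher number from compound 3 to compound 4 (0.93 log units; beyond the scatter)), so a single halogen on the ring does not by itself keep the number of compound 3. The second step (a 1.7-fold higher number from compound 2 to compound 4 (0.23 log units; within the scatter)) does not separate 3-fluorophenyl from 4-methoxyphenyl, which leaves 4-chlorophenyl as the only one of the three measured rings that stands apart from the others. Nothing at hand accounts for this difference.

The change alters the halogen and its place on the ring together, so the compounds shown cannot tell which of the two matters. As far as these compounds go, how an unsubstituted phenyl, a bromophenyl or a pyridyl ring would behave on this chain remains open.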